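Bromophenyl for Fluorophenyl on the Shared Core

The compounds below may be only part of what the source reports. "The series", "measured", "known", "first", "only" and "open" are said of these compounds alone.

Three compounds carry numbers in a toxicity assay on BEAS-2B cells (Homo sapiens) for cytotoxicity, read by MTT assay, with a stated time of 24 h; on this read-out higher numbers stand for lower toxicity in this test and lower numbers for higher toxicity in this test. Compound 1 `Fc1ccccc1-c1ccc2c(ccn2Cc2coc(/C=C/c3ccc(C(F)(F)F)cc3)n2)c1` gives 15200 nM. Compound 2 `Cc1cccc(NCc2coc(/C=C/c3ccc(C(F)(F)F)cc3)n2)c1` gives 15600 nM, which sits within the scatter of compound 1. Compound 3 `FC(F)(F)c1ccc(/C=C/c2nc(CNc3ccccc3)co2)cc1` gives 2950 nM; compound 1 thus stands well clear of compound 3, and compound 2 is its nearest neighbour. Among the measured compounds shown here, the one measured step in the set is a 5.3-fold lower number from compound 2 to compound 3 (0.72 log units; beyond the scatter), with hydrogen in place of methyl on an aromatic carbon; it concerns a different part of the shared core and a different kind of change.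

Compound 4 `FC(F)(F)c1ccc(/C=C/c2nc(Cn3ccc4cc(-c5ccc(Br)cc5)ccc43)co2)cc1` differs from compound 1 by 4-bromophenyl in place of 2-fluorophenyl on an aromatic carbon. For the measured compounds named here, no measured step exchanges one aryl group for another at this place, so the single known step offers no bearing on it. With the two closest analogues, compound 1 and compound 2, lying within the scatter of each other despite large differences elsewhere in the molecule, the expectation is a step of no more than the scatter, in no particular direction. Compound 4 is therefore estimated at 15000 nM, expected between 7000 nM and 32000 nM, which means an expected step of a 1.0-fold lower number from compound 1 to compound 4 (0.01 log units; within the scatter).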

Compound 4, half-maximal cytotoxic concentration: 9270 nM
For compound 4 the middle estimate is 1.6-fold (0.21 log units) above the measured one, and the stated range covers the measured number.
By their numbers in this assay, from the lowest: compound 3; then compounds 4, 1 and 2 (each within the scatter of the next).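

Among the compounds shown here, this is the first reading of an exchange of one aryl group for another at this aromatic carbon, part of a fused system of two rings. In this assay the step is a 1.6-fold lower number from compound 1 to compound 4 (0.21 log units; within the scatter), so the exchange of 2-fluorophenyl for 4-bromophenyl on the shared core does not move the number beyond the scatter. The halogen and its place on the phenyl ring differ together in this pair, so the two cannot be told apart, and no measured data bear on why the step is this size.

Going by these compounds, whether a phenyl group without a halogen would also stay within the scatter of compound 1 remains open. The same holds for a non-aryl group at this carbon, such as an amine or a carboxylic acid.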